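A few compounds are considered here, and "the series" means these few. Any claim that something is new, unique, unknown or untested is made for them only; others in the source may bear on it.

Working notes on the coumarin-free description: the shared core of compound 3 `Cc1ccc2oc(=O)c(/C=N/c3ccc(S(N)(=O)=O)cc3)c(Cl)c2c1` gives, in a functional assay on B16-F10 cells (Mus musculus) for cytotoxicity, read by CCK-8 assay, with a stated time of 48 h (on this read-out higher numbers stand for weaker inhibition and lower numbers for stronger inhibition), a value of 360 nM. Compound 1 `NS(=O)(=O)c1ccc(/N=C/c2c(Cl)c3ccccc3oc2=O)cc1` gives 300 nM in this assay, and compound 2 `CC(C)(C)c1cc(C(C)(C)C)c2oc(=O)c(/C=N/c3ccc(S(=O)(=O)NC(=N)N)cc3)c(Cl)c2c1` gives 250 nM; the gaps between compound 3 and each of these fall within the scatter, so compound 3 cannot be set apart from either on these numbers. Within the data shown here, the one measured step, a 1.2-fold higher number from compound 1 to compound 3 (0.08 log units; within the scatter), concerns a change on an aromatic carbon and does not touch the sulfonamide.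

Compound 4 `Cc1ccc2oc(=O)c(/C=N/c3ccc(S(=O)(=O)Nc4nccc(C)n4)cc3)c(Cl)c2c1` is not yet measured. It differs from compound 3 in one place: 4-methylpyrimidin-2-yl in place of hydrogen on a sulfonamide nitrogen. Among the measured compounds shown here, no measured step addresses a substituent on the sulfonamide nitrogen. Compound 2 carries a substituted sulfonamide nitrogen together with other changes, and its value and that of compound 3 lie within the scatter of each other, which is all that pair shows. For the measured compounds named here, with no step bearing directly on this change, no movement beyond the scatter is expected in this assay, and the step from compound 3 to compound 4 is estimated as a 1.0-fold lower number from compound 3 to compound 4 (0.01 log units; within the scatter). Compound 4 is therefore expected to give about 350 nM in this assay, with a range from 120 nM to 1000 nM.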

Compound 4, half-maximal inhibitory concentration: 270 nM
Compound 4: the middle estimate sits 1.3-fold (0.11 log units) above what was measured; measured number inside the range.
By their numbers in this assay, from the lowest: compounds 2, 4, 1 and 3 (each within the scatter of the next).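

In this assay, among these compounds, placing 4-methylpyrimidin-2-yl on the sulfonamide nitrogen in place of hydrogen gives a 1.3-fold lower number from compound 3 to compound 4 (0.12 log units; within the scatter), the first direct reading at this position, since the earlier single-place step concerned an aromatic carbon. For this one pair, the read-out stays within the scatter when the hydrogen on that nitrogen is lost and a six-membered aromatic ring with 2 hetero atoms enters, so neither that hydrogen nor a small substituent is needed for a number of this size. No measurement at hand bears on why this step is so small.

Still open, as far as these compounds go, is whether this tolerance is general for the sulfonamide nitrogen or specific to this group: a plain phenyl ring, an unsubstituted pyrimidin-2-yl, a methyl group, a longer alkyl chain, an amine or a carboxylic acid in the same place could each separate ring, ring nitrogens and ring methyl from one another. From the compounds shown here alone, it is also open whether 4-methylpyrimidin-2-yl behaves the same way on the core of compound 1, which lacks the methyl group of compound 3.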